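Fluoro in Place of Hydrogen on the Phenyl of Compound 1

A few compounds are considered here, and "the series" means these few. Any claim that something is new, unique, unknown or untested is made for them only; others in the source may bear on it.

Compound 1 `O=C1C2CCCN2C(=O)N1CN1CCN(c2ccccc2)CC1` is the reference point. Among the compounds with values here, in an assay on Cerebral cortex for binding affinity to Adrenergic receptor alpha-1 (Rattus norvegicus), read by radioligand binding (on this read-out lower numbers stand for stronger inhibition and higher numbers for weaker inhibition), compound 1 gives 2590 nM, the lowest of the two numbers measured so far; its nearest neighbour is compound 2 `O=C1C2CCCN2C(=O)N1CN1CCN(c2cccc(C(F)(F)F)c2)CC1`, which in this assay gives 3300 nM. Within the data shown here, the single measured step, a 1.3-fold higher number from compound 1 to compound 2 (0.11 log units; within the scatter), put trifluoromethyl in place of hydrogen on an aromatic carbon and stayed within the scatter. Compound 3 `O=C1C2CCCN2C(=O)N1CN1CCN(c2ccc(F)cc2)CC1` has not yet been measured; it differs from compound 1 by fluoro in place of hydrogen on an aromatic carbon. Among the measured compounds shown here, the only step that bears on this change is a 1.3-fold higher number from compound 1 to compound 2 (0.11 log units; within the scatter), a different group on the same ring that left the number essentially unchanged, so a small group on this ring is expected to move this assay little, with no step expected beyond the scatter. The expected step is a 1.1-fold higher number from compound 1 to compound 3 (0.03 log units; within the scatter). For compound 3 the estimate is 2800 nM, with a range from 1000 nM to 8000 nM.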

Compound 3, inhibition constant: 1190 nM
Beside the measured number, compound 3's estimate is 2.4-fold (0.37 log units) above it; measured number inside the range.
By their numbers in this assay, from the lowest: compound 3; then compounds 1 and 2 (each within the scatter of the next).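

In this assay, fluoro in place of hydrogen on an aromatic carbon, para to a large group, gives a 2.2-fold lower number from compound 1 to compound 3 (0.34 log units; beyond the scatter). Within the data shown here, this modest change is the first step on this ring to lie beyond the scatter, whereas the earlier trifluoromethyl change, a 1.3-fold higher number from compound 1 to compound 2 (0.11 log units; within the scatter), did not. The phenyl ring of compound 1 can therefore respond to a single added atom, although nothing available explains why this change lowers the number.

The compounds shown leave open whether this response is particular to fluoro or would also appear with chloro, methoxy or an amine at the same place. They also do not show whether fluoro on another carbon of this ring would give a similar step.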